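The source may hold more compounds than are shown below. What is called first, only, known or untested is meant among the compounds shown, and "the series" means these compounds.

In an in vitro ADME assay on microsomes from liver (Homo sapiens) for metabolic stability (on this read-out lower numbers stand for a shorter-lived compound and higher numbers for a longer-lived compound), compound 1 (`CS(=O)(=O)c1cccc(-c2cc(N3CC(N)C(c4cc(F)c(F)cc4F)C3)ncn2)c1`) gives > 3 h, which is a limit of the assay and not a number. Compound 2 (`CN(C)C(=O)c1cccc(-c2cc(N3CC(N)C(c4cc(F)c(F)cc4F)C3)ncn2)c1`) gives > 3 h, which is also a limit. The evidence so far is therefore (the limit of > 3 h in this assay, at which 2 of the 2 values shown sit). Compound 3 (`CS(=O)(=O)c1cc(F)cc(-c2cc(N3CC(N)C(c4cc(F)c(F)cc4F)C3)ncn2)c1`) keeps the core of compound 1 and changes it in one place: fluoro in place of hydrogen on an aromatic carbon, meta to a methylsulfonyl group (fluoro in place of hydrogen on an aromatic carbon). Going by the values given here, the only measured step, a step that the two limits leave unreadable from compound 1 to compound 2, concerns a different change and has no readable size, so it offers no size to carry over. Since compound 1 stands at the limit > 3 h, no step beyond the usual scatter is expected in this assay. The expected change is a step that the limit leaves unreadable from compound 1 to compound 3. For compound 3 the estimated half-life is 4.5 h, with an expected range from 2.5 h to 9 h.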

Compound 3, half-life: > 3 h
Compound 3 gave a limit, no number; the forecaster's own chance of this, stated with the estimate: 85%; the middle value lies beyond the limit too.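

Going by these compounds alone, compound 3 ends at a limit of this assay and not at a number, just as compound 1 does, so no step from compound 1 to compound 3 can be read: the limit of > 3 h in this assay, at which 3 of the 3 values shown sit.

The compounds shown leave open how long each one actually lasts, and whether the added fluoro changes that at all.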